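Removing the Acetyl Group Across Two Linker Lengths

The source may report more compounds than this note shows. Statements on the series, on what has been measured and on what is new or still open speak of the compounds shown alone.

Compound 1 `COc1cc2cc(NC(C)=O)c(=O)oc2cc1OCCCOc1no[n+]([O-])c1S(=O)(=O)c1ccccc1` and compound 2 `COc1cc2cc(NC(C)=O)c(=O)oc2cc1OCCCCOc1no[n+]([O-])c1S(=O)(=O)c1ccccc1` share an acetamido group but differ in their cores; how the two cores differ is not broken down here. In a functional assay on HepG2 cells (Homo sapiens) for inhibition, read by MTT assay, with a stated time of 48 h (on this read-out higher numbers stand for weaker inhibition and lower numbers for stronger inhibition), compound 1 gives 2820 nM, and compound 2 gives 3290 nM, the two values lying within the usual scatter of each other. Compound 3 `COc1cc2cc(N)c(=O)oc2cc1OCCCOc1no[n+]([O-])c1S(=O)(=O)c1ccccc1` arises from compound 1 by the change (hydrogen in place of acetyl on a nitrogen on an aromatic ring). In this assay compound 3 gives 2810 nM, so that a 1.0-fold lower number from compound 1 to compound 3 (0.00 log units; within the scatter). Compound 4 `COc1cc2cc(N)c(=O)oc2cc1OCCCCOc1no[n+]([O-])c1S(=O)(=O)c1ccccc1` has not yet been measured; it arises from compound 2 by the change (hydrogen in place of acetyl on a nitrogen on an aromatic ring), the same change made at the same kind of place, the second of two such occurrences among these compounds. Because the earlier step of a 1.0-fold lower number from compound 1 to compound 3 (0.00 log units; within the scatter) left the number unchanged, the step from compound 2 to compound 4 is expected to be of similar size, namely a 1.0-fold higher number from compound 2 to compound 4 (0.00 log units; within the scatter). Compound 4 is therefore estimated to give 3300 nM in this assay, with an expected range from 1800 nM to 6000 nM.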

Compound 4, half-maximal inhibitory concentration: 2640 nM
Estimate against measurement, compound 4: 1.3-fold (0.10 log units) above, and the stated range covers the measured number.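

In this assay, putting hydrogen in place of acetyl on the nitrogen gives a 1.2-fold lower number from compound 2 to compound 4 (0.10 log units; within the scatter), and this step can be set beside the earlier one: the same change on two cores in this assay, a 1.0-fold lower number (0.00 log units; within the scatter) from compound 1 to compound 3 and a 1.2-fold lower number (0.10 log units; within the scatter) from compound 2 to compound 4, 1.2-fold (0.09 log units) apart, within the scatter of two such steps. On both cores shown, then, going from acetamido to amino gives a step within the scatter, and the outcome seen on the core of compound 1 carries over to the core of compound 2. For the compounds shown here, this rests on only two pairs in a single cell assay, so it does not show that the change would behave the same way on any other core, or on any other read-out.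

The compounds shown carry only acetamido or amino on this nitrogen, leaving open whether a benzoyl group or a methyl group there would give a similar number. They also leave open whether the same step would hold on a core with a longer chain.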